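Adding a Carbonyl to the Side Group of Compound 3

A few compounds are considered here, and "the series" means these few. Any claim that something is new, unique, unknown or untested is made for them only; others in the source may bear on it.

Three measured compounds share one core:
- Compound 1, `Cc1nc(-c2ccc(OCCC(C)CCN3CCN(c4ccnc(N)c4)C3=O)cc2)no1`, gives 66100 nM in an ADME assay on RD cells (Homo sapiens) for cytotoxicity, read by MTT assay, with a stated time of 24 h; on this read-out lower numbers stand for higher toxicity in this test and higher numbers for lower toxicity in this test.
- Compound 2, `CC(CCOc1ccc(/C=N/O)cc1)CCN1CCN(c2ccnc(N)c2)C1=O`, sits at a limit of this assay, > 100000 nM.
- Compound 3, `CCONCc1ccc(OCCC(C)CCN2CCN(c3ccnc(N)c3)C2=O)cc1`, gives 7370 nM in this assay.

Compound 3 holds the lowest of the two plain numbers, so it is the most toxic compound measured here; the value of compound 2 is a limit, (the limit of > 100000 nM in this assay, at which 1 of the 3 values shown sits), and not a number. The nearest measured neighbour is compound 1, with a 9.0-fold lower number from compound 1 to compound 3 (0.95 log units; beyond the scatter), while the step from the oxime shows an at least 13-fold lower number from compound 2 to compound 3 (1.13 log units; beyond the scatter).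

Compound 4, `CCONC(=O)c1ccc(OCCC(C)CCN2CCN(c3ccnc(N)c3)C2=O)cc1`, is not yet measured. For the measured compounds named here, its single change is ethoxycarbamoyl in place of (ethoxyamino)methyl on an aromatic carbon. The two measured steps that touched this same position both moved the read-out well beyond the scatter, so the group in this place matters. Compound 4 keeps the ethoxy-nitrogen chain of compound 3 but gains a carbonyl, which brings it somewhat closer to the more polar groups of compound 1 and compound 2. A higher number than compound 3 is therefore expected, a 3.4-fold higher number from compound 3 to compound 4 (0.53 log units; beyond the scatter), but a smaller shift than those seen from compound 1 or compound 2. The estimate for compound 4 in this assay is 25000 nM, with a range from 8000 nM to 100000 nM.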

Compound 4, half-maximal cytotoxic concentration: > 100000 nM
Compound 4: only a limit was reported; the forecaster's own chance of this, stated with the estimate: 25%; middle value at least 4.0-fold (0.60 log units) from the limit.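

In this assay, for the compounds shown here, the carbonyl gives an at least 13-fold higher number from compound 3 to compound 4 (1.13 log units; beyond the scatter), even though the group that leaves and the group that enters have the same counts of hydrogen-bond donors and acceptors; the earlier steps exchanged more dissimilar groups and could not show that so small an edit at this place can produce a large step. Compound 3 now has steps beyond the scatter to all three other compounds, while the comparison with the oxadiazole gives an at least 1.5-fold higher number from compound 1 to compound 4 (0.17 log units; that floor lies within the scatter), so this result does not separate compound 4 clearly from compound 1. The value of compound 4 is a limit and not a number, as is that of compound 2, so the step between these two compounds cannot be read: the limit of > 100000 nM in this assay, at which 2 of the 4 values shown sit.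

From the compounds shown here alone, how far the true value of compound 4 lies beyond its limit remains open, so the full size of the carbonyl step is unknown. Also open, going by these compounds, is how the number would move with an aminomethyl group or a carboxylic acid at this place, or with a longer chain in place of the ethoxy end of compound 3 or compound 4.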